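The source may report more compounds than this note shows. Statements on the series, on what has been measured and on what is new or still open speak of the compounds shown alone.

Compound 1 `C=C[C@@]1(O)[C@@H](CO)O[C@@H](n2ccc(=O)[nH]c2=O)[C@@H]1O` carries a vinyl group on the shared core. In a functional assay on L1210 cells (Mus musculus), read by MTT assay (a higher number here means a weaker inhibitor, a lower number a stronger inhibitor), compound 1 gives 148000 nM, the higher of the two numbers recorded. Compound 3 `CC#C[C@@]1(O)[C@@H](CO)O[C@@H](n2ccc(N)nc2=O)[C@@H]1O` differs from compound 1 in its base as well as in its chain. In this assay compound 3 gives 24500 nM, a lower number that lies beyond the scatter. For compound 2 `C#CC[C@]1(O)[C@@H](CO)O[C@@H](n2ccc(=O)[nH]c2=O)[C@@H]1O` only a limit of the assay is reported, > 350000 nM, as noted in the limit of > 350000 nM in this assay, at which 1 of the 3 values shown sits. Compound 4 `CCC#C[C@@]1(O)[C@@H](CO)O[C@@H](n2ccc(=O)[nH]c2=O)[C@@H]1O` differs from compound 1 in one place: but-1-yn-1-yl in place of vinyl on a saturated ring carbon. Among the measured compounds shown here, with no single-change step recorded for the vinyl to but-1-yn-1-yl exchange on this base, compound 4 is expected to sit close to compound 1, a step of a 1.0-fold higher number from compound 1 to compound 4 (0.01 log units; within the scatter) that need not pass beyond the scatter, with an estimated value of 150000 nM in this assay and a range from 40000 nM to 400000 nM.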

Compound 4, half-maximal inhibitory concentration: 338000 nM
For compound 4 the middle estimate is 2.3-fold (0.35 log units) below the measured one, within the range that was stated.
By their numbers in this assay, from the lowest: compound 3; then compound 1; then compound 4. At a limit, above all of these: compound 2.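

Among the compounds shown here, on this saturated ring carbon, with the base unchanged, but-1-yn-1-yl in place of vinyl gives the first single-place step at this position: in this assay there is a 2.3-fold higher number from compound 1 to compound 4 (0.36 log units; beyond the scatter). The exchange therefore moves toward a weaker inhibitor, though only modestly. Compound 2 offers no number for comparison, only a limit of the assay: the limit of > 350000 nM in this assay, at which 1 of the 4 values shown sits.

Going by these compounds, what a saturated propyl chain or an aminomethyl group would do at this position remains open. Also open, on these data alone, is whether the same exchange would give a similar step on the base of compound 3.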